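The source may hold more compounds than are shown below. What is called first, only, known or untested is meant among the compounds shown, and "the series" means these compounds.

Of the compounds shown here, three built on one shared core have been measured in an assay for binding affinity to Alpha-1A adrenergic receptor (Homo sapiens), read by radioligand binding; a higher number here means a weaker inhibitor, a lower number a stronger inhibitor. Compound 1 `COc1ccc(S(C)(=O)=O)c(NCC2=NCCN2)c1` gives 1620 nM. For the measured compounds named here, compound 2 `CS(=O)(=O)c1ccc(F)cc1NCC1=NCCN1` gives 813 nM, and the only single-point step among the measured compounds is a 2.0-fold lower number from compound 1 to compound 2 (0.30 log units; within the scatter). Compound 3 `CSc1ccc(C(F)(F)F)cc1NCC1=NCCN1` gives 589 nM, a number that sits within the scatter of compound 2 and differs from compound 1 by more than the scatter; compound 2 and compound 3 differ in two places, so their values can only be set side by side. Compound 4 `CS(=O)(=O)c1ccc(C(F)(F)F)cc1NCC1=NCCN1` has not yet been measured. It differs from compound 3 by methylsulfonyl in place of methylsulfanyl on an aromatic carbon. Going by the values given here, no measured step exchanges methylsulfanyl for methylsulfonyl, and the one step on record, fluoro in place of methoxy, says nothing about this exchange. The expectation for compound 4 in this assay is therefore a step of a 1.0-fold higher number from compound 3 to compound 4 (0.01 log units; within the scatter), nothing beyond the scatter in either direction. Compound 4 is estimated at 600 nM, with a range from 200 nM to 1800 nM.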

Compound 4, inhibition constant: < 12600 nM
Compound 4: a limit, no number; the forecaster's own chance of this, stated with the estimate: 5%; the middle value is on the limit's open side.
By their numbers in this assay, from the lowest: compounds 3, 2 and 1 (each within the scatter of the next, the first and the last beyond it).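

In this assay compound 4 gives < 12600 nM and this is a limit, not a number. For the compounds shown here, no step to compound 4 from compound 1, compound 2 or compound 3 can be read. The compounds shown leave open what methylsulfonyl in place of methylsulfanyl does to the number in this assay.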